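The compounds below may be only part of what the source reports. "The series", "measured", "known", "first", "only" and "open" are said of these compounds alone.

Compound 1, `O=C(O)COCCCC[C@H]1[C@H](F)CC[C@@H]1NS(=O)(=O)c1ccc(F)cc1F`: 1800 nM
Compound 2, `O=C(O)CC/C=C\C[C@@H]1[C@@H](CNS(=O)(=O)c2ccc(F)cc2)CC[C@@H]1F`: 650 nM
Compound 3, `O=C(O)COCCCCC1=CCC[C@@H]1NS(=O)(=O)c1ccc(Cl)c(Cl)c1`: 1900 nM

These three compounds were measured in a functional assay on a cell-free system (plasma) for inhibition of thromboxane A2 receptor (Homo sapiens), read by turbidimetry; a lower number here means a stronger inhibitor, a higher number a weaker inhibitor. Compound 3 gives the highest of the three numbers, so it is the weakest inhibitor here; its value and that of compound 1 are close to each other and sit within the usual scatter, while compound 2 shows a clearly lower number than compound 3, beyond the scatter. Compound 1 and compound 2 are built on cores different from that of compound 3, so they do not speak directly to the change followed next.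

Compound 4, `Cc1ccc(S(=O)(=O)N[C@H]2CCC=C2CCCCOCC(=O)O)cc1`, has not been measured. It differs from compound 3 in one place: 4-methylphenyl in place of 3,4-dichlorophenyl on a sulfonyl sulfur. Within the data shown here, nothing measured so far shows this exchange on any core, so the expectation rests only on the values of the three compounds and on the fact that the rest of compound 3 is kept unchanged. A step of this kind is expected to stay small, and if anything to go towards a somewhat higher number, as a 1.3-fold higher number from compound 3 to compound 4 (0.12 log units; within the scatter) is estimated. Compound 4 is therefore expected to show about 2500 nM in this assay, with a likely range from 800 nM to 8000 nM.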

Compound 4, half-maximal inhibitory concentration: 1900 nM
Compound 4: middle estimate off by 1.3-fold (0.12 log units), on the high side; low and high end bracket the measured number.
By their numbers in this assay, from the lowest: compound 2; then compounds 1, 3 and 4 (each within the scatter of the next).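

On the shared core, 4-methylphenyl in place of 3,4-dichlorophenyl on a sulfonyl sulfur gives no change at the digits printed from compound 3 to compound 4 (within the scatter) in this assay. Among these compounds, this pair is the first direct look at this position, since the earlier compounds differ from one another in more than one place: here the chlorine atoms leave, a methyl-bearing ring takes over, and the assay registers no difference between the two compounds. No measurement at hand accounts for this sameness, so it stands as a plain observation about one pair on one core.

Still open, going by these compounds, is whether the same exchange would read the same way on the core of compound 1 or the core of compound 2, as neither is linked to this pair by a single change. Also open, on these data alone, is how much variation this position accepts, since a pyridine ring, a 4-methoxyphenyl group or a simple cyclohexyl group on the sulfonyl sulfur could either match these two compounds or part from them clearly.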